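Replacing a phenylethynyl group with trifluoromethyl on a fused core

The compounds below may be only part of what the source reports. "The series", "measured", "known", "first", "only" and "open" are said of these compounds alone.

Compound 3 `O=c1nc2c(ncn2Cc2ccccc2)c(C#Cc2ccccc2)n1Cc1ccccc1` was tested in a functional assay on K562 cells (Homo sapiens) for cytotoxicity, read by thymidine incorporation, with a stated time of 48 h, tested at 10 ug/mL (on this read-out higher numbers stand for more inhibition at the one concentration tested (going by the name of the read-out) and lower numbers for less inhibition), where compound 3 gives 100%. Two related compounds share the fused core with the same two benzyl groups. Compound 1 `O=C1Nc2c(ncn2Cc2ccccc2)C(C#CC2CC2)N1Cc1ccccc1` gives 98% in this assay, and compound 2 `CC1c2ncn(Cc3ccccc3)c2NC(=O)N1Cc1ccccc1` gives 98%. The number of compound 3 stands at the top of the three, yet its gaps to compound 1 and to compound 2 lie within the usual scatter, so the three cannot be told apart on these data.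

Compound 4 `O=c1nc2c(ncn2Cc2ccccc2)c(C(F)(F)F)n1Cc1ccccc1` has not yet been measured. It differs from compound 3 in one place: trifluoromethyl in place of 2-phenylethynyl on an aromatic carbon. Within the data shown here, the only measured step, no change at the digits printed from compound 1 to compound 2 (within the scatter), also removed a group carrying a triple bond and left a small group in its stead, on a saturated ring carbon of the core, without moving the number. The change from compound 3 to compound 4 likewise trades a group with a triple bond for a small one, here on an aromatic carbon. On that single precedent, the step of a number 5 percentage points lower from compound 3 to compound 4 (within the scatter) is expected to stay within the scatter. Compound 4 is therefore estimated to give 95% in this assay, expected to fall between 82% and 100%.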

Compound 4, a percentage reported as inhibition, at one concentration (the size of the read-out at that concentration, not a potency): 11%
Estimate against measurement, compound 4: 84 percentage points above; measured number outside the range, below it.
By their numbers in this assay, from the lowest: compound 4; then compounds 1, 2 and 3 (each within the scatter of the next).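

In this assay, the step of a number 89 percentage points lower from compound 3 to compound 4 (beyond the scatter) shows that the group on this aromatic carbon, ortho to a benzyl group, can decide the size of the read-out, since this single change takes away most of the inhibition seen with 2-phenylethynyl. Exchanging a group that carries a triple bond for a small one therefore has no uniform outcome in these compounds: the step of no change at the digits printed from compound 1 to compound 2 (within the scatter) on a saturated ring carbon goes against the large step seen here, although that pair also differs from this one in the group that leaves and the group that enters. Nothing available on these compounds explains the large step.

The change removes the six-membered carbon ring and the triple bond and brings in fluorine all at once, so the compounds shown cannot say which of these matters for the read-out. A phenyl ring joined directly to this aromatic carbon, without the triple bond, would begin to separate the ring from the triple bond, and an amine or a longer carbon chain at the same carbon would show how broadly this place accepts other groups.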